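The source may hold more compounds than are shown below. What is called first, only, known or untested is meant among the compounds shown, and "the series" means these compounds.

Working notes on the series.

Of the compounds shown here, three have been measured in a functional assay on HepG2 cells (Homo sapiens) for inhibition, read by CCK-8 assay, with a stated time of 48 h; a higher number here means a weaker inhibitor, a lower number a stronger inhibitor. Compound 1 `O=C1CSC(N2N=C(c3ccc(Br)cc3)CC2c2ccc3ccccc3c2)=N1` gives 18200 nM in this assay. Compound 2 `O=C1CSC(N2N=C(c3ccc(Cl)cc3)CC2c2ccc3ccccc3c2)=N1` gives 20400 nM in this assay. Compound 3 `Clc1ccc(C2=NN(C3=NC(c4ccccc4)CS3)C(c3cccc4ccccc34)C2)cc1` gives 18700 nM in this assay. The three numbers sit close together, and every gap among them is within the usual scatter, so no order of potency among compound 1, compound 2 and compound 3 is claimed.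

Compound 1 and compound 2 differ in one place: bromo in place of chloro on an aromatic carbon. The step that this change made is a 1.1-fold lower number from compound 2 to compound 1 (0.05 log units; within the scatter), which is within the scatter.

Compound 2 and compound 3 share the substituted phenyl but differ in their cores; the difference between the two cores is not broken down here.

Compound 4 `Brc1ccc(C2=NN(C3=NC(c4ccccc4)CS3)C(c3cccc4ccccc34)C2)cc1` has not been measured in this assay. It stands to compound 3 as compound 1 stands to compound 2: bromo in place of chloro on an aromatic carbon. The place of the change is described in the same words for both pairs, so it is the same change, carried out on the core of compound 3 instead of the core of compound 2.

The expectation for compound 4 rests on a single precedent: because the earlier instance gave a 1.1-fold lower number from compound 2 to compound 1 (0.05 log units; within the scatter), the step from compound 3 to compound 4 is expected to be a 1.1-fold lower number from compound 3 to compound 4 (0.03 log units; within the scatter), again within the scatter. Compound 4 is therefore estimated at 17500 nM in this assay, with the likely range running from 9000 nM to 35000 nM. With one precedent and a different core, the range is kept wide.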

Compound 4, half-maximal inhibitory concentration: 15600 nM
Compound 4: the middle estimate sits 1.1-fold (0.05 log units) above what was measured, and the stated range covers the measured number.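

In this assay, bromo in place of chloro on the core of compound 3 gives a 1.2-fold lower number from compound 3 to compound 4 (0.08 log units; within the scatter), so the 4-chlorophenyl to 4-bromophenyl change produces no step beyond the scatter on this core. Set beside the earlier instance, the two steps cannot be told apart, and the change reads the same on both cores: the same change on two cores in this assay, a 1.1-fold lower number (0.05 log units; within the scatter) from compound 2 to compound 1 and a 1.2-fold lower number (0.08 log units; within the scatter) from compound 3 to compound 4, 1.1-fold (0.03 log units) apart, within the scatter of two such steps. This shows that on these two cores the exchange of one halogen for the other leaves the number within the scatter; it does not show that bromo is truly better than chloro, since neither step can be separated from repeat-to-repeat variation, and two cores give no basis for a statement about other cores in the series.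

From the compounds shown here alone, with only chloro and bromo at this place on the phenyl ring, it remains open whether a clearly different group there, such as an amine, a carboxylic acid or a longer chain, would give a step beyond the scatter in this assay. Going by these compounds, it also remains open whether such a step would carry from one core to the other, a question that two steps within the scatter cannot test.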